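Two Diterpenoid Dimers Differing Only in Stereochemistry

The source may report more compounds than this note shows. Statements on the series, on what has been measured and on what is new or still open speak of the compounds shown alone.

compound 1 `CC(C)c1cc2c(c(O)c1O)[C@]13CO[C@H]2C[C@H]1C(C)(C)C[C@H](O)C3`: > 10000 nM
compound 2 `CC(C)C1=C[C@@]23Oc4c(C(C)C)cc5c(c4O[C@]2(C(=O)C1=O)[C@]12CO[C@@H]3C[C@H]1C(C)(C)C[C@H](O)C2)[C@]12CO[C@@H]5C[C@H]1C(C)(C)C[C@H](O)C2`: > 10000 nM

In a functional assay on NCI-H460 cells (Homo sapiens) for cytotoxicity, read by MTT assay (a higher number here means a weaker inhibitor, a lower number a stronger inhibitor), compound 1 gives > 10000 nM, a limit of the assay rather than a number. In this assay compound 2 also gives only a limit, > 10000 nM. The whole picture so far is the limit of > 10000 nM in this assay, at which 2 of the 2 values shown sit. Compound 3 `CC(C)C1=C[C@]23Oc4c(C(C)C)cc5c(c4O[C@@]2(C(=O)C1=O)[C@]12CO[C@@H]3C[C@H]1C(C)(C)C[C@H](O)C2)[C@]12CO[C@@H]5C[C@H]1C(C)(C)C[C@H](O)C2` keeps every atom and bond of compound 2; (the two compounds have the same atoms and bonds and differ only in configuration as drawn: 2 of 10 stereo elements differ; a stereocentre at a saturated ring carbon is drawn S in compound 2 and R in compound 3; a stereocentre at a saturated ring carbon is drawn R in compound 2 and S in compound 3). Among the measured compounds shown here, no measured pair differs in one place, so no step size is known. From compound 2 to compound 3 no change beyond the scatter is expected, a step that the limit leaves unreadable from compound 2 to compound 3. Compound 3 is therefore expected to give 15000 nM, between 5000 nM and 50000 nM, most likely reported once more only as a limit.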

Compound 3, half-maximal inhibitory concentration: 8500 nM
Compound 3: middle estimate off by 1.8-fold (0.25 log units), on the high side; the measured number falls inside the stated range.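

In this assay compound 3 gives 8500 nM, a measured number. This shows that two compounds with the same atoms and bonds need not both stay at the limit. The only difference lies in the configuration at two saturated ring carbons, and the step reads an at least 1.1-fold lower number from compound 2 to compound 3 (0.07 log units; that floor lies within the scatter). Its true size cannot be read, and the floor alone shows no real gain.

As far as these compounds go, whether either stereocentre alone matters stays open. So does what an amine or a carboxylic acid on the shared core would do in this assay.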